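The source may hold more compounds than are shown below. What is called first, only, known or untested is meant among the compounds shown, and "the series" means these compounds.

Compound 2 `CC(=O)Nc1ccc(-c2nc3cc(C(F)(F)F)ccc3[nH]2)cc1` gives the only number shown in an ADME assay on Vero cells (Chlorocebus sabaeus) for cytotoxicity; a higher number here means that more compound is tolerated, a lower number that less compound is tolerated: in this assay compound 2 gives 50000 nM. Among the compounds with values here, the one further value is a limit. Compound 1 `CCC(=O)Nc1ccc(-c2nc3cc(C(F)(F)F)ccc3[nH]2)cc1` reaches > 100000 nM in this assay, which is the limit of > 100000 nM in this assay, at which 1 of the 2 values shown sits. Between these two compounds the step reads an at least 2.0-fold lower number from compound 1 to compound 2 (0.30 log units; that floor lies within the scatter), and its floor lies within the scatter. Compound 3 `O=C(CN1CCCC1)Nc1ccc(-c2nc3cc(C(F)(F)F)ccc3[nH]2)cc1` differs from compound 2 in one place: pyrrolidin-1-yl in place of hydrogen on a saturated chain carbon bound to a carbonyl carbon. Within the data shown here, only the step from compound 1 to compound 2 touches the same saturated chain carbon, and it gives no sign of a step beyond the scatter, so for the entry of pyrrolidin-1-yl no measured step speaks for a change in either direction. Compound 3 is therefore expected to give about 50000 nM in this assay, with an estimated range from 20000 nM to 150000 nM. The step this estimate means for compound 3 is expected to be no change at the digits printed from compound 2 to compound 3 (within the scatter).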

Compound 3, half-maximal cytotoxic concentration: > 100000 nM
Compound 3: a limit, no number; the forecaster's own chance of this, stated with the estimate: 35%; middle value at least 2.0-fold (0.30 log units) from the limit.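

In this assay, pyrrolidin-1-yl on the saturated chain carbon bound to a carbonyl carbon gives an at least 2.0-fold higher number from compound 2 to compound 3 (0.30 log units; that floor lies within the scatter). This place therefore takes a group of 5 heavy atoms with a five-membered non-aromatic ring without any lower number, where earlier only methyl had been seen on it. Compound 3, like compound 1, ends at a limit and not at a number: the limit of > 100000 nM in this assay, at which 2 of the 3 values shown sit. The step between compound 1 and compound 3 cannot be read, both values being limits, so methyl and pyrrolidin-1-yl cannot be put in order here.

On these data alone, how far beyond the limit compound 1 and compound 3 lie stays open. Also open, as far as these compounds go, is whether a dimethylamino group, a morpholin-4-yl ring or a carboxylic acid on the same carbon would stay at that limit or fall back towards compound 2.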